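Replacing the Oxazolidinone Side Chain with a Thioether

The source may hold more compounds than are shown below. What is called first, only, known or untested is meant among the compounds shown, and "the series" means these compounds.

Compound 1 `CC(C)c1n[nH]c2c(NCc3ccc(-c4ccccn4)cc3)nc(SCC3CNC(=O)O3)nc12` was tested in a functional assay on HT cells (Homo sapiens) for antiproliferative activity, read by fluorescence, with a stated time of 72 h (on this read-out lower numbers stand for stronger inhibition of growth and higher numbers for weaker inhibition of growth), where compound 1 gives 80 nM. Among the three numbers measured, this stands second highest. Compound 2 `CNCCSc1nc(NCc2ccc(-c3ccccn3)cc2)c2[nH]nc(C(C)C)c2n1` gives 56 nM in this assay, and compound 3 `CC(C)c1n[nH]c2c(NCc3ccc(-c4ccccn4)cc3)nc(SC3CCCC3O)nc12` gives 567 nM. The step of a 1.4-fold lower number from compound 1 to compound 2 (0.15 log units; within the scatter) stays within the scatter, whereas a 7.1-fold higher number from compound 1 to compound 3 (0.85 log units; beyond the scatter) and a 10-fold higher number from compound 2 to compound 3 (1.01 log units; beyond the scatter) both go beyond it.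

Compound 4 `CSCCSc1nc(NCc2ccc(-c3ccccn3)cc2)c2[nH]nc(C(C)C)c2n1` has not yet been measured. It differs from compound 1 by (methylsulfanyl)methyl in place of 2-oxo-1,3-oxazolidin-5-yl on a saturated chain carbon bound to a sulfur. The most relevant comparison is the step in which an open chain with a donor took the place of the ring on the sulfur: a 1.4-fold lower number from compound 1 to compound 2 (0.15 log units; within the scatter). Within the data shown here, compound 4 also carries an open chain there, but without a donor, and no measured pair shows what removing that donor from the chain does. The larger step of a 7.1-fold higher number from compound 1 to compound 3 (0.85 log units; beyond the scatter) concerns a ring on the sulfur rather than a chain, so it bears only loosely on the question. The estimate for compound 4 therefore corresponds to a step of a 1.9-fold higher number from compound 1 to compound 4 (0.27 log units; within the scatter), close to the edge of the scatter. Compound 4 is expected to give about 150 nM in this assay, with a likely range from 50 nM to 450 nM.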

Compound 4, concentration for 50% growth inhibition: 975 nM
Compound 4: middle estimate off by 6.5-fold (0.81 log units), on the low side, and the stated range ends below it.
By their numbers in this assay, from the lowest: compounds 2 and 1 (each within the scatter of the next); then compounds 3 and 4 (each within the scatter of the next).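

In this assay, the new result shows that an open chain on the sulfur does not in itself hold the number low, since exchanging methylamino for methylsulfanyl on the saturated chain carbon gives a 17-fold higher number from compound 2 to compound 4 (1.24 log units; beyond the scatter), a large step from a change at the end of the chain alone. The 2-oxo-1,3-oxazolidin-5-yl group is therefore not interchangeable with just any chain end: (methylamino)methyl in its place stayed within the scatter, whereas (methylsulfanyl)methyl gives a 12-fold higher number from compound 1 to compound 4 (1.09 log units; beyond the scatter), and the result falls in the same range as the 2-hydroxycyclopentyl group, with a 1.7-fold higher number from compound 3 to compound 4 (0.24 log units; within the scatter) lying within the scatter. The data shown offer no measurement that explains why the methylamino and methylsulfanyl chain ends differ so widely.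

The compounds shown leave open which feature of the methylamino end matters, and whether a primary amine, a dimethylamino group or a methoxy group at the same chain end would track compound 2 or compound 4. They also leave open whether a longer chain carrying methylamino, or a carboxylic acid in its place, would keep the number of compound 2.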